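This account rests on a few compounds, and the source may have more. Where it says the series, first, only, none or still open, it means among the compounds named here.

Measured so far in an ADME assay on Huh-7 cells (Homo sapiens) for cytotoxicity, with a stated time of 72 h; a lower number here means that less compound is tolerated, a higher number that more compound is tolerated:
Compound 1 `CC(C)(C)CCn1nc(-c2cccs2)c(O)c(C2=NS(=O)(=O)c3cc(NS(C)(=O)=O)ccc3N2)c1=O` gives > 1000 nM as a limit.
Compound 2 `CCC(C)CCn1nc(-c2cccs2)c(O)c(C2=NS(=O)(=O)c3cc(NS(C)(=O)=O)ccc3N2)c1=O` gives > 1000 nM as a limit.
Compound 3 `CC(C)Cn1nc(-c2cccs2)c(O)c(C2=NS(=O)(=O)c3cc(NS(C)(=O)=O)ccc3N2)c1=O` gives > 1000 nM as a limit.

Compound 3 therefore has no number to its name, only a limit, and it cannot be ranked against compounds 1 and 2. All the evidence rests on one point (the limit of > 1000 nM in this assay, at which 3 of the 3 values shown sit) and on nothing finer.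

Compound 4 `CS(=O)(=O)Nc1ccc2c(c1)S(=O)(=O)N=C(c1c(O)c(-c3cccs3)nn(CCC3CCCCC3)c1=O)N2` differs from compound 3 in one place (cyclohexylmethyl in place of isopropyl on a saturated chain carbon bound to an aromatic nitrogen), with cyclohexylmethyl in place of isopropyl on a saturated chain carbon bound to an aromatic nitrogen. The same difference, cut one bond further out, reads isobutyl to 2-cyclohexylethyl.

Within the data shown here, the steps that bear on it alter this same chain: a step that the two limits leave unreadable from compound 1 to compound 2, a step that the two limits leave unreadable from compound 1 to compound 3 and a step that the two limits leave unreadable from compound 2 to compound 3. None has a readable size, and none brings in a ring, so the guidance is weak. No step beyond the scatter is expected in this assay, and no direction can be argued. The expectation rests on compound 3, whose limit is > 1000 nM in that read-out. The expected step is a step that the limit leaves unreadable from compound 3 to compound 4 as estimated here. Another limit is the likeliest report. For compound 4 the estimate is 1500 nM, with an expected range from 700 nM to 5000 nM.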

Compound 4, half-maximal cytotoxic concentration: > 17000 nM
Compound 4 ended at the assay's limit; the forecaster's own chance of this, stated with the estimate: 75%; middle value at least 11-fold (1.05 log units) away from the limit.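

In this assay compound 4 gives > 17000 nM, which is a limit and not a number. Among these compounds, compounds 1, 2 and 3 also carry only limits, so no step from any of them to compound 4 can be read. The compounds shown leave open whether the chain on the aromatic nitrogen, including the 2-cyclohexylethyl of compound 4, alters the tolerated concentration at all.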